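Inverting the carbinol centre of compound 2

The source may hold more compounds than are shown below. What is called first, only, known or untested is meant among the compounds shown, and "the series" means these compounds.

Measured in an ADME assay on MT4 cells (Homo sapiens) for cytotoxicity, read by MTT assay, with a stated time of 5 days; a lower number here means that less compound is tolerated, a higher number that more compound is tolerated:
- compound 1 `COc1cc(-c2ccc(C#N)cc2)ccc1[C@@H](O)c1ccnc(Nc2ccc(C#N)cc2)n1`: 33100 nM
- compound 2 `N#Cc1ccc(Nc2nccc([C@@H](O)c3ccc(-c4ccc(C#N)cc4)cc3Cl)n2)cc1`: 4250 nM

Compound 2 carries the lower of the two numbers, and its gap to compound 1 lies beyond the usual scatter. Compound 3 `N#Cc1ccc(Nc2nccc([C@H](O)c3ccc(-c4ccc(C#N)cc4)cc3Cl)n2)cc1` departs from compound 2 as follows: the two compounds have the same atoms and bonds and differ only in configuration as drawn: 1 of 1 stereo elements differ; a stereocentre at a saturated chain carbon is drawn S in compound 2 and R in compound 3. For the measured compounds named here, no measured pair isolates a change of configuration, so the expectation rests only on compound 2 at 4250 nM, with no step beyond the scatter foreseen in either direction. The estimated change is a 1.2-fold higher number from compound 2 to compound 3 (0.07 log units; within the scatter). For compound 3 the expected value is 5000 nM, within a range of 1800 nM to 14000 nM.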

Compound 3, half-maximal cytotoxic concentration: 28100 nM
For compound 3 the middle estimate is 5.6-fold (0.75 log units) below the measured one, and the stated range ends below it.
By their numbers in this assay, from the lowest: compound 2; then compounds 3 and 1 (each within the scatter of the next).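

In this assay, the configuration at the saturated chain carbon proves to be a real lever on its own, with a 6.6-fold higher number from compound 2 to compound 3 (0.82 log units; beyond the scatter). The step can be assigned to this stereocentre because nothing else changes: the fact that compounds 2 and 3 differ only in the configuration as drawn

Chloro in place of methoxy on an aromatic carbon gives a 1.2-fold lower number from compound 1 to compound 3 (0.07 log units; within the scatter), so that exchange does not separate this pair. From the compounds shown here alone, whether configuration has a comparable effect with methoxy on the aromatic carbon remains open. Also open, going by these compounds, is how an amine or a methyl ether in place of the hydroxyl at this carbon would read.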